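The source may hold more compounds than are shown below. What is called first, only, known or untested is meant among the compounds shown, and "the series" means these compounds.

Measured so far:
- compound 1, `COc1ccc(C#N)cc1CSc1nc2cc(NC(=O)C3CC3)ccc2n1C(C)C`: 570 nM
- compound 2, `CCCn1c(SCc2cc([N+](=O)[O-])ccc2OC)nc2cc(NC(=O)NC(C)(C)C)ccc21`: 18 nM

Going by the values given here, in an assay on isolated protein for inhibition of Gonadotropin-releasing hormone receptor (Homo sapiens) (on this read-out lower numbers stand for stronger inhibition and higher numbers for weaker inhibition), compound 2 gives 18 nM, and this is the lower of the two numbers measured so far. Among the compounds with values here, compound 1, the only other compound measured, gives 570 nM in this assay, so compound 2 stands as the stronger inhibitor of the two, with a gap well beyond the usual scatter.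

Compound 3, `COc1ccc([N+](=O)[O-])cc1CSc1nc2cc(NC(=O)NC(C)(C)C)ccc2n1-c1ccccc1`, has not yet been measured. It differs from compound 2 in one place: phenyl in place of propyl on an aromatic nitrogen. Within the data shown here, no step between two measured compounds shows how a change of this kind plays out, so the direction is open. The expectation is a modest step, with a loss of potency somewhat more likely than a gain, from compound 2 to compound 3 of a 2.5-fold higher number from compound 2 to compound 3 (0.40 log units; beyond the scatter) in this assay. Compound 3 is estimated at 45 nM, within a range from 8 nM to 250 nM.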

Compound 3, half-maximal inhibitory concentration: 350 nM
For compound 3 the middle estimate is 7.8-fold (0.89 log units) below the measured one, and the stated range ends below it.
By their numbers in this assay, from the lowest: compound 2; then compounds 3 and 1 (each within the scatter of the next).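

Swapping propyl for phenyl on the aromatic nitrogen gives a 19-fold higher number from compound 2 to compound 3 (1.29 log units; beyond the scatter) in this assay. Going by these compounds alone, this is the first direct reading of this position, as the two earlier compounds differ in more than one place. It shows that the group on this nitrogen matters a great deal for this read-out, and that here phenyl is far less well tolerated than propyl, though no measurement shown explains why.

One step cannot show how this position responds to other groups, such as whether ethyl, butyl or benzyl on the same nitrogen would give a number closer to that of compound 2 or that of compound 3. From the compounds shown here alone, it also remains open whether the same swap would cost as much with a different group elsewhere on the shared core.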